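Replacing a thioether chain with a pyridylethoxy chain

The compounds below may be only part of what the source reports. "The series", "measured", "known", "first", "only" and "open" are said of these compounds alone.

Compound 1, `COc1cccc(CCOc2ccc(-c3c(C)nc(C)c([C@H](OC(C)(C)C)C(=O)O)c3N3CCC(C)(C)CC3)cc2)c1`: in an ADME assay on microsomes from liver (Homo sapiens) for metabolic stability, read by LC-MS, tested at 0.5 uM (a higher number here means that the compound lasts longer, a lower number that the compound disappears faster), compound 1 gives > 2 h, which is a limit of the assay.
Compound 2, `Cc1cc(CCOc2ccc(-c3c(C)nc(C)c([C@H](OC(C)(C)C)C(=O)O)c3N3CCC(C)(C)CC3)cc2)ccc1F`: in this assay compound 2 gives > 2 h, again a limit.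
Compound 3, `Cc1nc(C)c([C@H](OC(C)(C)C)C(=O)O)c(N2CCC(C)(C)CC2)c1-c1ccc(SCCc2ccc(F)cc2)cc1`: in this assay compound 3 gives > 2 h, also a limit.

Compound 3 therefore stands at the same limit as the other two measured compounds; no number separates them, as the limit of > 2 h in this assay, at which 3 of the 3 values shown sit, records. The step to the unmeasured compound 4, `Cc1nc(C)c([C@H](OC(C)(C)C)C(=O)O)c(N2CCC(C)(C)CC2)c1-c1ccc(OCCc2ccccn2)cc1`, is 2-(pyridin-2-yl)ethoxy in place of (2-(4-fluorophenyl)ethyl)sulfanyl on an aromatic carbon. The measured steps that touch the same position are a step that the two limits leave unreadable from compound 1 to compound 3, a step that the two limits leave unreadable from compound 2 to compound 3 and, one position further along, a step that the two limits leave unreadable from compound 1 to compound 2; all three are unreadable in size, since both ends sit at the limit. They show only that exchanging the chain on that aromatic carbon has not pulled any compound below the limit. With nothing in the shown data pointing either way, the expected step of a number no higher from compound 3 to compound 4 (the limit leaves the size open) in this assay is one of no readable size beyond the scatter. Compound 4 is accordingly estimated at 2 h, with a range from 0.8 h to 4 h, most likely reported again only as a limit.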

Compound 4, half-life: 0.5 h
Compound 4: middle estimate off by 4.0-fold (0.60 log units), on the high side, and the stated range ends above it.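

In this assay, going by these compounds alone, 2-(pyridin-2-yl)ethoxy in place of (2-(4-fluorophenyl)ethyl)sulfanyl gives an at least 4.0-fold lower number from compound 3 to compound 4 (0.60 log units; beyond the scatter), the first readable change at this position, since the steps among compound 1, compound 2 and compound 3 cannot be read. Compound 1 and compound 2 carry the same ethoxy link as compound 4, and with that link kept, pyridin-2-yl at the end of the chain in place of 4-fluoro-3-methylphenyl gives an at least 4.0-fold lower number from compound 2 to compound 4 (0.60 log units; beyond the scatter), while pyridin-2-yl in place of 3-methoxyphenyl gives an at least 4.0-fold lower number from compound 1 to compound 4 (0.60 log units; beyond the scatter), so the oxygen in the chain does not go with the drop on its own. All three steps give only a smallest size, because the other end of each sits at a limit: the limit of > 2 h in this assay, at which 3 of the 4 values shown sit.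

The compounds shown leave open whether the drop belongs to the ring nitrogen as such or to its place in the ring, which pyridin-3-yl or pyridin-4-yl on the same ethoxy chain would separate. They also leave open whether pyridin-2-yl behaves the same way on the sulfanyl chain, and how an unsubstituted phenyl at the end of the ethoxy chain would compare.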